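The source may hold more compounds than are shown below. What is called first, only, known or untested is meant among the compounds shown, and "the series" means these compounds.

Among the compounds with values here, compound 2 `CS(=O)(=O)c1ccc(C(=O)NCCC(=O)N2CCCc3ccccc32)cc1[N+](=O)[O-]` is the one member of the series that gives a number in an ADME assay on HepG2 cells (Homo sapiens) for cytotoxicity, read by CellTiter-Glo and ATP content, with a stated time of 72 h; on this read-out higher numbers stand for an effect only at larger amounts of compound and lower numbers for an effect already at smaller amounts: compound 2 gives 10500 nM. Compound 1 `CS(=O)(=O)c1ccc(C(=O)NCCC(=O)N2CCCCC2)cc1[N+](=O)[O-]` sits at a limit of the assay, > 27000 nM. Compound 3 `CCCN(C(=O)CN(C)C(=O)c1ccc(S(C)(=O)=O)c([N+](=O)[O-])c1)c1ccccc1` likewise sits at a limit, > 27000 nM; two of the three values therefore stand at the limit of > 27000 nM in this assay, at which 2 of the 3 values shown sit. Within the data shown here, the one step measured at the amide position, an at least 2.5-fold lower number from compound 1 to compound 2 (0.41 log units; beyond the scatter), runs toward lower numbers.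

Compound 4 `CC(C)N(C(=O)CCNC(=O)c1ccc(S(C)(=O)=O)c([N+](=O)[O-])c1)C(C)C` differs from compound 2 by diisopropylamino in place of 1,2,3,4-tetrahydroquinolin-1-yl on a carbonyl carbon. The move from piperidinyl to the fused ring gave an at least 2.5-fold lower number from compound 1 to compound 2 (0.41 log units; beyond the scatter); the reverse direction, to a ring-free amine, is expected to give a number larger than that of compound 2. For compound 4 the estimate is 25000 nM, range 10000 nM to 60000 nM, a step of a 2.4-fold higher number from compound 2 to compound 4 (0.38 log units; beyond the scatter) expected, with a fair chance of only a limit.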

Compound 4, half-maximal effective concentration: > 27000 nM
Compound 4: only a limit was reported (the forecaster's own chance of this, stated with the estimate: 50%); middle value at least 1.0-fold (0.03 log units) from the limit.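

Replacing 1,2,3,4-tetrahydroquinolin-1-yl with diisopropylamino on the carbonyl carbon gives an at least 2.5-fold higher number from compound 2 to compound 4 (0.41 log units; beyond the scatter) in this assay, so the lower number of compound 2 now stands against a ring-free amine as well as against piperidin-1-yl. Compound 4 gives only a limit of the assay, > 27000 nM. The step from compound 1 to compound 4 joins two limits and cannot be read, and compound 2 remains the only one with a number: the limit of > 27000 nM in this assay, at which 3 of the 4 values shown sit.

Open, as far as these compounds go, is whether indolin-1-yl on the same carbonyl carbon would also give a number rather than a limit. From the compounds shown here alone, how far the true values of compound 1 and compound 4 lie beyond their limits also stays unknown.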